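This account rests on a few compounds, and the source may have more. Where it says the series, first, only, none or still open, it means among the compounds named here.

Working notes on the series. Compound 3 `COc1cccc(-c2cc(=O)c3cc(OCCCCCCN4CCC(O)CC4)ccc3o2)c1` gives 111 nM in an assay on isolated protein (Cavia porcellus) with Sigma non-opioid intracellular receptor 1 (Homo sapiens) as the target, read by radioligand binding; on this read-out lower numbers stand for stronger inhibition and higher numbers for weaker inhibition. Compound 1 `O=c1cc(-c2ccccc2)oc2cccc(OCCCCN3CCC(O)CC3)c12` gives 177 nM in this assay, and compound 2 `CN(C)CCCCOc1ccc2oc(-c3ccccc3)cc(=O)c2c1` gives 400 nM. Compound 3 thus has the lowest of the three numbers; its gap to compound 1 lies within the scatter, so no order between these two is claimed, while its gap to compound 2 lies beyond the scatter.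

Compound 4 `O=c1cc(C2CCCC2)oc2ccc(OCCCCCCN3CCC(O)CC3)cc12` differs from compound 3 by cyclopentyl in place of 3-methoxyphenyl on an aromatic carbon. Going by the values given here, no measured pair in this set shows the same change, so there is no step to lean on. A modest move toward a higher number, if any, is expected in this assay; the step from compound 3 to compound 4 is estimated at a 2.3-fold higher number from compound 3 to compound 4 (0.35 log units; beyond the scatter). Compound 4 is expected to give about 250 nM, within a range from 80 nM to 800 nM.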

Compound 4, half-maximal inhibitory concentration: 55 nM
Beside the measured number, compound 4's estimate is 4.5-fold (0.66 log units) above it; measured number below the stated range.
By their numbers in this assay, from the lowest: compounds 4, 3 and 1 (each within the scatter of the next, the first and the last beyond it); then compound 2.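

In this assay, cyclopentyl in place of 3-methoxyphenyl on the aromatic carbon next to the ring oxygen gives a 2.0-fold lower number from compound 3 to compound 4 (0.30 log units; within the scatter). In this pair, the substituent at this position need not be aromatic or carry a hydrogen-bond acceptor for the number to stay at the level of compound 3. The compounds shown leave open whether cyclohexyl or tert-butyl at this position would keep that level, and whether a longer chain would alter the outcome of this change. No measurement at hand accounts for this result.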